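Cyano to Acetamido on the Triazole Aryl Group

This account rests on a few compounds, and the source may have more. Where it says the series, first, only, none or still open, it means among the compounds named here.

Measured compounds:
- compound 1, `COc1ccc([C@@H]2C/C(=N/OCc3cn(-c4ccccc4CO)nn3)c3cc(CC=C(C)C)c(OC)cc3O2)cc1`: 100%
- compound 2, `COc1ccc([C@@H]2C/C(=N/OCc3cn(-c4ccc(C(=O)c5ccccc5)cc4)nn3)c3cc(CC=C(C)C)c(OC)cc3O2)cc1`: 41%
- compound 3, `COc1ccc([C@@H]2C/C(=N/OCc3cn(-c4ccc(C#N)cc4)nn3)c3cc(CC=C(C)C)c(OC)cc3O2)cc1`: 40%

In a functional assay on MCF7 cells (Homo sapiens) for inhibition, read by sulforhodamine B assay, with a stated time of 48 h, tested at 50 uM (a lower number here means less inhibition of growth, a higher number more inhibition of growth at the concentration tested), compound 3 gives the lowest of the three numbers. Its nearest neighbour is compound 2, which lies only slightly higher, within the scatter; compound 1 lies far above it, beyond the scatter. The shared core carries a triazole whose aromatic nitrogen bears a phenyl ring, and the three compounds differ only in what sits on that phenyl ring.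

Compound 4, `COc1ccc([C@@H]2C/C(=N/OCc3cn(-c4ccc(NC(C)=O)cc4)nn3)c3cc(CC=C(C)C)c(OC)cc3O2)cc1`, is not yet measured. Its change from compound 3 is acetamido in place of cyano on an aromatic carbon.

For the measured compounds named here, two measured steps bear on this change. The step of a number 60 percentage points lower from compound 1 to compound 3 (beyond the scatter) swaps the whole substituent pattern on the phenyl ring and is large. The step of a number 1 percentage points lower from compound 2 to compound 3 (within the scatter) exchanges one group for another at the same place as the change to compound 4 and stays within the scatter. Because a number 1 percentage points lower from compound 2 to compound 3 (within the scatter) shows that replacing the group at this position leaves this assay little changed, a small step is expected for compound 4, of about a number 5 percentage points higher from compound 3 to compound 4 (within the scatter). Compound 4 is therefore estimated at 45%, with a range from 25% to 70%.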

Compound 4, percent growth inhibition at one concentration: 0%
Compound 4: the middle estimate sits 45 percentage points above what was measured, outside the stated range (below it).
By their numbers in this assay, from the lowest: compound 4; then compounds 3 and 2 (each within the scatter of the next); then compound 1.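

In this assay, this place on the phenyl ring proves able to move the number a long way: acetamido in place of cyano gives a number 40 percentage points lower from compound 3 to compound 4 (beyond the scatter) and acetamido in place of benzoyl gives a number 41 percentage points lower from compound 2 to compound 4 (beyond the scatter), whereas the earlier exchange of benzoyl for cyano stayed within the scatter. Compound 4 therefore stands apart from both neighbours, and the comparison of whole aryl groups, 4-acetamidophenyl in place of 2-(hydroxymethyl)phenyl, gives a number 100 percentage points lower from compound 1 to compound 4 (beyond the scatter). The data shown offer no explanation for this loss of inhibition. The compounds shown leave open which part of acetamido goes with the loss. A plain amine or a longer chain on the amide carbonyl at this place would help separate the two parts, and a carboxylic acid there would test a further kind of group.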